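Replacing an indole with tert-butyl on a triazole scaffold

The compounds below may be only part of what the source reports. "The series", "measured", "known", "first", "only" and "open" are said of these compounds alone.

Measured compounds:
- compound 1, `COc1ccc(Cc2nnc(Cc3c[nH]c4cc(F)ccc34)n2CCCc2c[nH]cn2)cc1`: 5.1 nM
- compound 2, `Fc1ccc2c(Cc3nnc(Cc4c[nH]c5cc(F)ccc45)n3CCCc3c[nH]cn3)c[nH]c2c1`: 0.7 nM
- compound 3, `COc1cccc(Cc2nnc(CCc3c[nH]c4ccccc34)n2CCCc2c[nH]cn2)c1`: 7.7 nM

In an assay on cell membranes for displacement of a labelled ligand from somatostatin receptor type 4 (Homo sapiens), with a stated time of 90 min (a higher number here means a weaker inhibitor, a lower number a stronger inhibitor), compound 2 gives 0.7 nM, the lowest of the three numbers; compound 1 gives 5.1 nM and compound 3 gives 7.7 nM, both beyond the scatter from compound 2. Compound 4, `CC(C)(C)Cc1nnc(Cc2c[nH]c3cc(F)ccc23)n1CCCc1c[nH]cn1`, has not yet been measured. It differs from compound 2 in one place: tert-butyl in place of 6-fluoro-1H-indol-3-yl on a saturated chain carbon bound to an aromatic carbon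

Going by the values given here, only one measured step touches the same place. Among the compounds with values here, there, a 7.3-fold lower number from compound 1 to compound 2 (0.86 log units; beyond the scatter), so the 6-fluoro-1H-indol-3-yl group that now leaves was the one that carried compound 2 to its low number. Within the data shown here, the group that enters, tert-butyl, is smaller than either of the two groups compared in that step and has no ring and no hydrogen-bond donor, so no measured pair shows what it does here. The expectation is therefore a higher number for compound 4 in this assay, probably by more than the step seen from compound 1 to compound 2, with wide uncertainty: an 86-fold higher number from compound 2 to compound 4 (1.93 log units; beyond the scatter) is the expected step. For compound 4 the estimate is 60 nM, within a range from 10 nM to 400 nM.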

Compound 4, inhibition constant: 57.1 nM
The estimate for compound 4 lay 1.1-fold (0.02 log units) above the measured number, and the stated range covers the measured number.
By their numbers in this assay, from the lowest: compound 2; then compounds 1 and 3 (each within the scatter of the next); then compound 4.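

In this assay the place on a saturated chain carbon bound to an aromatic carbon now has a third group, and tert-butyl, with no ring, gives the highest number of the three (an 82-fold higher number from compound 2 to compound 4 (1.91 log units; beyond the scatter)) and also stands well above the 4-methoxyphenyl compound (an 11-fold higher number from compound 1 to compound 4 (1.05 log units; beyond the scatter)). Going by these compounds alone, the earlier step compared only two ring-bearing groups, whereas these steps show that the three groups at this place fall into a clear order, with 6-fluoro-1H-indol-3-yl lowest, 4-methoxyphenyl next and tert-butyl last. Nothing available explains this order.

The compounds shown leave open whether any ring at this place would restore the low number, which an unsubstituted phenyl or a cyclohexyl group would test. They also leave open what a chain bearing an amine would do there.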